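Side-chain swap on compound 1 toward compound 4

The compounds below may be only part of what the source reports. "The series", "measured", "known", "first", "only" and "open" are said of these compounds alone.

In a physicochemical assay for lipophilicity, read by HPLC, measured as octanol-water partition (on this read-out higher numbers stand for higher lipophilicity and lower numbers for lower lipophilicity), compound 1 `O=C1CNC(=O)N1C[C@H]1CN(c2ccc(-n3cc(-c4ccccn4)cn3)c(F)c2)C(=O)O1` gives 1.25, the second highest of three numbers. Compound 2 `O=C1CSC(=O)N1C[C@H]1CN(c2ccc(-n3cc(-c4ccccn4)cn3)c(F)c2)C(=O)O1` gives 2.18, and compound 3 `O=CNC[C@H]1CN(c2ccc(-n3cc(-c4ccccn4)cn3)c(F)c2)C(=O)O1` gives 1.19, within the scatter of compound 1. The two steps from compound 1 read a number 0.93 log units higher from compound 1 to compound 2 (beyond the scatter) and a number 0.06 log units lower from compound 1 to compound 3 (within the scatter). Compound 4 `CN(C)S(=O)(=O)NC[C@H]1CN(c2ccc(-n3cc(-c4ccccn4)cn3)c(F)c2)C(=O)O1` differs from compound 1 as follows: (dimethylsulfamoyl)amino in place of 2,5-dioxoimidazolidin-1-yl on a saturated chain carbon bound to a saturated ring carbon. The counts of heavy atoms, donors and acceptors match between the leaving and entering groups, and the ring is opened, as in the step to compound 3. Because a number 0.06 log units lower from compound 1 to compound 3 (within the scatter) stayed within the scatter, compound 4 is expected to sit near compound 1, moving by a number 0.25 log units higher from compound 1 to compound 4 (within the scatter). The estimate for compound 4 is 1.5, ranging from 1 to 2.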

Compound 4, partition coefficient: 1.38
Beside the measured number, compound 4's estimate is 0.12 log units above it; low and high end bracket the measured number.
By their numbers in this assay, from the lowest: compounds 3, 1 and 4 (each within the scatter of the next); then compound 2.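

In this assay, (dimethylsulfamoyl)amino stays within the scatter of both 2,5-dioxoimidazolidin-1-yl (a number 0.13 log units higher from compound 1 to compound 4 (within the scatter)) and formylamino (a number 0.19 log units higher from compound 3 to compound 4 (within the scatter)), so at this position three different groups now read alike. Sulfur in the entering group does not by itself bring the number of compound 2, which stands apart (a number 0.80 log units lower from compound 2 to compound 4 (beyond the scatter)). No evidence on hand accounts for these steps.

From the compounds shown here alone, whether the number of compound 2 belongs to its ring or to its ring sulfur remains open. Going by these compounds, how a basic amine or a carboxylic acid on this saturated chain carbon would read also remains open.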